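A few compounds are considered here, and "the series" means these few. Any claim that something is new, unique, unknown or untested is made for them only; others in the source may bear on it.

Compound 1, `CC(C)CCn1cnc2c(Nc3ccc(Cl)cc3)nc(N[C@H]3CC[C@H](N)CC3)nc21`: 2700 nM. Compound 2, `CC(C)CCn1cnc2c(Nc3cccc(O)c3)nc(N[C@H]3CC[C@H](N)CC3)nc21`: 12600 nM. Compound 3, `COc1ccc(Nc2nc(N[C@H]3CC[C@H](N)CC3)nc3c2ncn3CCC(C)C)c(OC)c1`: 6300 nM.

These three share one core and differ only in the aryl group on a nitrogen on an aromatic ring. In a functional assay on MCF7 cells (Homo sapiens) for inhibition, read by fluorescence, with a stated time of 72 h (a higher number here means a weaker inhibitor of growth, a lower number a stronger inhibitor of growth), compound 3 stands second highest of the three numbers. Its nearest neighbour is compound 2, and the step of a 2.0-fold lower number from compound 2 to compound 3 (0.30 log units; within the scatter) lies within the scatter, while the step of a 2.3-fold higher number from compound 1 to compound 3 (0.37 log units; beyond the scatter) lies beyond it. Compound 4, `CC(C)CCn1cnc2c(Nc3ccc(O)cc3)nc(N[C@H]3CC[C@H](N)CC3)nc21`, has not yet been measured. The change from compound 3 is 4-hydroxyphenyl in place of 2,4-dimethoxyphenyl on a nitrogen on an aromatic ring. Among the measured compounds shown here, no measured step matches this exactly. The step of a 4.7-fold higher number from compound 1 to compound 2 (0.67 log units; beyond the scatter) shows that a hydroxyphenyl group gave a clearly higher number than 4-chlorophenyl, and a 2.0-fold lower number from compound 2 to compound 3 (0.30 log units; within the scatter) shows that 2,4-dimethoxyphenyl and 3-hydroxyphenyl give numbers within the scatter of each other. Because compound 2 gives 12600 nM with a hydroxyphenyl group, the number for compound 4, which also carries a hydroxyphenyl group, is expected to sit near that of compound 2 or compound 3. The step of a 1.4-fold higher number from compound 3 to compound 4 (0.15 log units; within the scatter) is therefore expected to be small, at most a modest rise. Compound 4 is estimated at 9000 nM, with a range from 3000 nM to 27000 nM.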

Compound 4, concentration for 50% growth inhibition: 3100 nM
Compound 4: middle estimate off by 2.9-fold (0.46 log units), on the high side; low and high end bracket the measured number.
By their numbers in this assay, from the lowest: compounds 1 and 4 (each within the scatter of the next); then compounds 3 and 2 (each within the scatter of the next).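

In this assay, 4-hydroxyphenyl in place of 3-hydroxyphenyl gives a 4.1-fold lower number from compound 2 to compound 4 (0.61 log units; beyond the scatter), so the two hydroxyphenyl groups on this nitrogen are clearly distinct, and carrying a hydroxyphenyl group does not by itself set the number here. Hydroxy in place of chloro on the aromatic carbon gives a 1.1-fold higher number from compound 1 to compound 4 (0.06 log units; within the scatter), so 4-hydroxyphenyl and 4-chlorophenyl cannot be told apart in this assay, and the gap seen earlier between 4-chlorophenyl and 3-hydroxyphenyl therefore cannot be read as a general difference between chloro and hydroxy. The change from 2,4-dimethoxyphenyl to 4-hydroxyphenyl gives a 2.0-fold lower number from compound 3 to compound 4 (0.31 log units; beyond the scatter), a modest step that places compound 4 with compound 1 rather than with compound 2 or compound 3.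

The compounds shown leave open whether a 3-chlorophenyl group would differ from 4-chlorophenyl as 3-hydroxyphenyl differs from 4-hydroxyphenyl, and how a 4-methoxyphenyl or 4-aminophenyl group would compare with these four compounds. Nothing given here accounts for any of these differences in growth inhibition.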